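Swapping a Fluorinated Phenyl for a Dimethoxyphenyl

The compounds below may be only part of what the source reports. "The series", "measured", "known", "first", "only" and "open" are said of these compounds alone.

Of the compounds shown here, three built on one shared core have been measured in a functional assay on WM 266-4 cells (Homo sapiens) for antiproliferative activity, read by MTT assay, with a stated time of 24 h; on this read-out lower numbers stand for stronger inhibition of growth and higher numbers for weaker inhibition of growth. Compound 1 `Clc1cccc(C2CC(c3ccc4c(c3)OCCO4)=NN2c2ccccc2)c1` gives 1750 nM. Compound 2 `Brc1ccc(C2CC(c3ccc4c(c3)OCCO4)=NN2c2ccccc2)cc1` gives 3010 nM in this assay. Compound 3 `Fc1ccccc1C1CC(c2ccc3c(c2)OCCO3)=NN1c1ccccc1` gives 9120 nM in this assay. Compound 3 carries the highest number of the three: the steps of a 5.2-fold higher number from compound 1 to compound 3 (0.72 log units; beyond the scatter) and a 3.0-fold higher number from compound 2 to compound 3 (0.48 log units; beyond the scatter) both lie beyond the scatter, while a 1.7-fold higher number from compound 1 to compound 2 (0.24 log units; within the scatter) does not.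

Compound 4 `COc1ccc(C2CC(c3ccc4c(c3)OCCO4)=NN2c2ccccc2)cc1OC` differs from compound 3 in one place: 3,4-dimethoxyphenyl in place of 2-fluorophenyl on a saturated ring carbon. Within the data shown here, no measured step exchanges a fluorinated phenyl for one bearing methoxy groups, so nothing measured speaks directly to this change. The measured steps only show that exchanging one substituted phenyl on this saturated ring carbon for another shifted the numbers in this assay by modest amounts, with compound 3 at the weak end. With no closer guide, compound 4 is expected to land near the middle of the measured spread, which would correspond to an expected step of a 2.6-fold lower number from compound 3 to compound 4 (0.42 log units; beyond the scatter). Compound 4 is therefore estimated at 3500 nM, within a range from 1000 nM to 15000 nM.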

Compound 4, concentration for 50% growth inhibition: 2160 nM
The estimate for compound 4 lay 1.6-fold (0.21 log units) above the measured number; the measured number falls inside the stated range.
By their numbers in this assay, from the lowest: compounds 1, 4 and 2 (each within the scatter of the next); then compound 3.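

Placing 3,4-dimethoxyphenyl on this saturated ring carbon in place of 2-fluorophenyl gives a 4.2-fold lower number from compound 3 to compound 4 (0.63 log units; beyond the scatter) in this assay, so the numbers at this position can also be reached by a phenyl that carries no halogen. The phenyls bearing chlorine and bromine are not set apart from the new group, since a 1.4-fold lower number from compound 2 to compound 4 (0.14 log units; within the scatter) and a 1.2-fold higher number from compound 1 to compound 4 (0.09 log units; within the scatter) both stay within the scatter. Of these four compounds, only compound 3 stands apart from the others, and a halogen on the phenyl does not by itself decide the outcome, as compound 1 and compound 2 carry one and so does compound 3.

Nothing measured here gives a reason for these differences. Still open, as far as these compounds go, is whether a phenyl with a single methoxy group would behave like compound 4, and whether an amine or a carboxylic acid on this phenyl would keep the number in the same range.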